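The source may report more compounds than this note shows. Statements on the series, on what has been measured and on what is new or still open speak of the compounds shown alone.

Of the compounds shown here, two have been measured so far in a functional assay on A549 cells (Homo sapiens) for cytotoxicity, read by MTT assay, with a stated time of 48 h; on this read-out lower numbers stand for stronger inhibition and higher numbers for weaker inhibition. Compound 1, `COc1cc(OC)c(-n2cc(CO/N=C3\CC[C@]4(C)[C@@H](CC/C=C(\C)CC/C=C(\C)CCC=C(C)C)[C@](C)(O)CC[C@H]4C3(C)C)nn2)c(OC)c1`, gives 8120 nM in this assay. Compound 2, `COc1cccc(-n2cc(COc3ccc(/C=C4\C[C@]5(C)[C@@H](CC/C=C(\C)CC/C=C(\C)CCC=C(C)C)[C@](C)(O)CC[C@H]5C(C)(C)C4=O)cc3)nn2)c1`, gives 45700 nM in this assay. Compound 2 therefore shows the highest number of the two, and the gap to compound 1 lies beyond the usual scatter of the measurement.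

Compound 3, `COc1cc(OC)c(-n2cc(COc3ccc(/C=C4\C[C@]5(C)[C@@H](CC/C=C(\C)CC/C=C(\C)CCC=C(C)C)[C@](C)(O)CC[C@H]5C(C)(C)C4=O)cc3)nn2)c(OC)c1`, is not yet measured. It keeps the whole core of compound 2 and changes only the group on the aromatic nitrogen: 2,4,6-trimethoxyphenyl in place of 3-methoxyphenyl on an aromatic nitrogen. Among the compounds with values here, the only hint about this group comes from compound 1, which carries the same 2,4,6-trimethoxyphenyl on a different core and gives the lower number.

A modest step downward is expected, of a size near the edge of the scatter, with the step from compound 2 to compound 3 estimated at a 1.8-fold lower number from compound 2 to compound 3 (0.26 log units; within the scatter). Compound 3 is expected to reach about 25000 nM in this assay, within a range from 8000 nM to 70000 nM.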

Compound 3, half-maximal inhibitory concentration: 16100 nM
For compound 3 the middle estimate is 1.6-fold (0.19 log units) above the measured one, and the stated range covers the measured number.
By their numbers in this assay, from the lowest: compounds 1 and 3 (each within the scatter of the next); then compound 2.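

Within the data shown here, on the aromatic nitrogen of the five-membered ring, replacing 3-methoxyphenyl with 2,4,6-trimethoxyphenyl in this assay gives a 2.8-fold lower number from compound 2 to compound 3 (0.45 log units; beyond the scatter) and provides the first reading of this change on one unchanged core. Until now, 2,4,6-trimethoxyphenyl had appeared only on the different core of compound 1, so its contribution could not be separated from that of the core. The step shows that this position responds to the swap, although no measurement here accounts for the shift.

Among these compounds, with only two groups tested at this position on this core, the data cannot show whether the number of methoxy groups or their placement matters. A plain phenyl or a benzyl group at the same nitrogen would help separate the ring itself from its methoxy groups.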